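From nitro to fluoro at the limit of the assay

This account rests on a few compounds, and the source may have more. Where it says the series, first, only, none or still open, it means among the compounds named here.

Compound 1 `O=C(/C=C\c1ccc(O)cc1)N1N=C(c2ccncc2)OC1c1c[nH]c2ccccc12` and compound 2 `O=C(/C=C\c1cccc([N+](=O)[O-])c1)N1N=C(c2ccncc2)OC1c1c[nH]c2ccccc12` have both been read, and neither gave a number. In an ADME assay on HeLa cells (Homo sapiens) for cytotoxicity, read by MTT assay, with a stated time of 72 h (on this read-out lower numbers stand for stronger inhibition of growth and higher numbers for weaker inhibition of growth), compound 1 gives > 30 ug/mL as a limit of the assay. In this assay compound 2 gives > 30 ug/mL as a limit as well, so no number places it. The record shows the limit of > 30 ug/mL in this assay, at which 2 of the 2 values shown sit, and nothing finer.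

Compound 3 `O=C(/C=C\c1cccc(F)c1)N1N=C(c2ccncc2)OC1c1c[nH]c2ccccc12` carries fluoro in place of nitro on an aromatic carbon of compound 2, meta to a large group, counted as fluoro in place of nitro on an aromatic carbon in full. Within the data shown here, the only measured step is a step that the two limits leave unreadable from compound 1 to compound 2 and it offers no size to carry over, so no size or direction for this assay can be drawn from it. The expected step is therefore a step that the limit leaves unreadable from compound 2 to compound 3 with no firm direction, and another limit reading is likely. For compound 3 the estimate is 40 ug/mL with an expected range from 15 ug/mL to 100 ug/mL as its ends.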

Compound 3, concentration for 50% growth inhibition: > 30 ug/mL
Compound 3: only a limit was reported (the forecaster's own chance of this, stated with the estimate: 75%); the middle value lies beyond the limit too.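

Compound 3 ends at a limit of the assay, as compound 1 and compound 2 do, so no step among these three compounds can be read: the limit of > 30 ug/mL in this assay, at which 3 of the 3 values shown sit.

The compounds shown leave open how far the 4-hydroxyphenyl, 3-nitrophenyl and 3-fluorophenyl compounds differ in this assay and whether they differ at all.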